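Methyl for Chloro: Expected Step in Receptor Binding

The source may report more compounds than this note shows. Statements on the series, on what has been measured and on what is new or still open speak of the compounds shown alone.

In an assay on HEK293 cells for displacement of a labelled ligand from 5-hydroxytryptamine receptor 7 (Homo sapiens), read by scintillation counting, with a stated time of 1.5 h, in the absence of a further agent (on this read-out higher numbers stand for weaker inhibition and lower numbers for stronger inhibition), compound 1 `CNCc1cccc(-c2ccccc2OC)c1` gives 226 nM.
In this assay compound 2 `CNCc1ccc(Cl)c(-c2ccccc2OC)c1` gives 5.2 nM.

Compound 2 stands at the lowest number of the two. Among the compounds with values here, the only measured step is a 43-fold lower number from compound 1 to compound 2 (1.64 log units; beyond the scatter). Compound 3 `CNCc1ccc(C)c(-c2ccccc2OC)c1` differs from compound 2 by methyl in place of chloro on an aromatic carbon. That single step bears on this change only indirectly, since it shows how much the chloro added over hydrogen, and the methyl is expected to keep a good part of that gain. Compound 3 is therefore expected to show a 2.9-fold higher number from compound 2 to compound 3 (0.46 log units; beyond the scatter) in this assay, a modest rise around the edge of the scatter. Compound 3 is estimated at 15 nM, with a range from 4 nM to 60 nM.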

Compound 3, inhibition constant: 15 nM
Estimate against measurement, compound 3: no gap at the digits printed; the measured number falls inside the stated range.
By their numbers in this assay, from the lowest: compound 2; then compound 3; then compound 1.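

Methyl in place of hydrogen on this aromatic carbon, para to a (methylamino)methyl group, gives a 15-fold lower number from compound 1 to compound 3 (1.18 log units; beyond the scatter), so the large gain at this position is not confined to chloro. Methyl in place of chloro still gives a 2.9-fold higher number from compound 2 to compound 3 (0.46 log units; beyond the scatter), which places chloro ahead of methyl here. No evidence at hand explains this order. The compounds shown leave open how a fluoro, methoxy or trifluoromethyl group on this carbon would compare with chloro and methyl. They also leave open whether a longer chain, such as ethyl, would keep the gain.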